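The source may hold more compounds than are shown below. What is called first, only, known or untested is meant among the compounds shown, and "the series" means these compounds.

Working notes on the series, all read in a functional assay on DU-145 cells (Homo sapiens) for inhibition, read by WST assay, with a stated time of 3 days; a higher number here means a weaker inhibitor, a lower number a stronger inhibitor. Compound 1 `CCCn1ccnc1/C=C/C(=O)/C=C/c1coc2ccccc2c1=O` gives 4600 nM, and compound 2 `CCCCCn1ccnc1/C=C/C(=O)/C=C/c1coc2ccccc2c1=O` gives 2700 nM. Going by the values given here, these are the only two numbers so far, and they lie within the scatter of each other, so compound 2 cannot be separated from compound 1.

Compound 3 `CC(C)n1ccnc1/C=C/C(=O)/C=C/c1coc2ccccc2c1=O` keeps the shared core and differs from compound 2 by one group: isopropyl in place of pentyl on an aromatic nitrogen. This is isopropyl in place of pentyl on an aromatic nitrogen, the nitrogen of the five-membered aromatic ring that carries the chain in all three compounds.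

Among the compounds with values here, one measured step bears on this change: a 1.7-fold lower number from compound 1 to compound 2 (0.23 log units; within the scatter). That step, ethyl in place of hydrogen on a saturated chain carbon, stays within the scatter. Within the data shown here, no compound with isopropyl has been measured, so the evidence is indirect. No step beyond the scatter is expected in this assay, with a small lean towards a higher number since compound 1 gives 4600 nM. The estimated change is a 1.5-fold higher number from compound 2 to compound 3 (0.17 log units; within the scatter). For compound 3 the estimated value is 4000 nM, with an expected range of 2000 nM to 8000 nM.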

Compound 3, half-maximal inhibitory concentration: 3300 nM
Compound 3: the middle estimate sits 1.2-fold (0.08 log units) above what was measured, and the stated range covers the measured number.
By their numbers in this assay, from the lowest: compounds 2, 3 and 1 (each within the scatter of the next).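

In this assay, isopropyl in place of pentyl on the aromatic nitrogen gives a 1.2-fold higher number from compound 2 to compound 3 (0.09 log units; within the scatter) and so stays within the scatter, and the same holds for isopropyl in place of propyl, with a 1.4-fold lower number from compound 1 to compound 3 (0.14 log units; within the scatter) as the step. Compounds 1 and 2 carry only unbranched chains, so compound 3 adds what they could not show: branching at the chain carbon attached to this nitrogen, with 3 heavy atoms in place of 5 against compound 2, leaves the reading inseparable from both of the other compounds, and all three values stand within the scatter of one another. No measurement on these compounds offers an explanation for this result.

As far as these compounds go, whether a chain longer than pentyl, a benzyl group, or a chain ending in an amine or a carboxylic acid on this nitrogen would bring a step beyond the scatter stays open. All three compounds share the rest of the core unchanged, so they say nothing about how the number responds to a change anywhere other than this aromatic nitrogen.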